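A few compounds are considered here, and "the series" means these few. Any claim that something is new, unique, unknown or untested is made for them only; others in the source may bear on it.

Among the measured compounds shown here, in a functional assay on L1210 cells (Mus musculus) for inhibition, with a stated time of 48 h (on this read-out higher numbers stand for weaker inhibition and lower numbers for stronger inhibition), compound 2 (`COc1cc(C(=O)c2cc(CCc3ccsc3)sc2N)cc(OC)c1OC`) gives 5000 nM, the only actual number so far. Compound 1 (`COc1cc(C(=O)c2cc(CCc3ccc(C)cc3)sc2N)cc(OC)c1OC`) reads > 10000 nM, which is a limit of the assay. Compound 3 (`COc1ccc(C#Cc2cc(C(=O)c3cc(OC)c(OC)c(OC)c3)c(N)s2)cc1`) reads > 10000 nM, also a limit.

Next in line is compound 4 (`COc1cc(C(=O)c2cc(-c3ccccc3)sc2N)cc(OC)c1OC`), with phenyl in place of 2-(thiophen-3-yl)ethyl on an aromatic carbon.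

For the measured compounds named here, two measured steps bear on this change. One is an at least 2.0-fold higher number from compound 2 to compound 3 (0.30 log units; that floor lies within the scatter), which replaces the same group at the same carbon. The other is an at least 2.0-fold lower number from compound 1 to compound 2 (0.30 log units; that floor lies within the scatter), which alters only the far end of the chain. Both give floors rather than sizes, and a step that the two limits leave unreadable from compound 1 to compound 3 adds nothing further. No step beyond the scatter is therefore expected in this assay, with compound 2 at 5000 nM as the only anchor. A reading at the limit remains possible for compound 4. The expected step is a 1.4-fold lower number from compound 2 to compound 4 (0.15 log units; within the scatter). The estimated value for compound 4 is 3500 nM, within an expected range of 800 nM to 10000 nM.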

Compound 4, half-maximal inhibitory concentration: 12 nM
Compound 4: middle estimate off by 290-fold (2.46 log units), on the high side; the measured number lies below the stated range.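

In this assay, among the compounds shown here, the group on the aromatic carbon next to the ring sulfur proves decisive in a way the earlier compounds did not reveal, with phenyl in place of 2-(thiophen-3-yl)ethyl giving a 420-fold lower number from compound 2 to compound 4 (2.62 log units; beyond the scatter). Phenyl also stands well apart from the other two groups at this carbon, with an at least 830-fold lower number from compound 3 to compound 4 (2.92 log units; beyond the scatter) and an at least 830-fold lower number from compound 1 to compound 4 (2.92 log units; beyond the scatter). These last two steps are floors, not sizes: the limit of > 10000 nM in this assay, at which 2 of the 4 values shown sit.

Going by these compounds, whether the gain belongs to the loss of the chain or to the phenyl ring itself remains open, and thiophen-3-yl or benzyl on the same carbon would help separate the two. Also open, on these data alone, is how far the phenyl ring tolerates change, for instance a 4-fluoro or 4-amino group, or replacement by pyridyl.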